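Fluoro on the benzamide in a thiazole antiproliferative series

The source may report more compounds than this note shows. Statements on the series, on what has been measured and on what is new or still open speak of the compounds shown alone.

Four compounds share one core, a thiazole that carries a substituted anilino group and a benzamido-bearing phenyl ring. Compound 1 `CCOC(=O)c1sc(-c2cccc(NC(=O)c3ccccc3)c2)nc1Nc1ccc(N2CCN(C)CC2)cc1` gives in a functional assay on Ramos cells (Homo sapiens) for antiproliferative activity, read by CCK-8 assay, with a stated time of 72 h, tested at 40 uM (a lower number here means less inhibition, a higher number more inhibition at the concentration tested (going by the name of the read-out)), a value of 77.1%. Compound 2 `CCOC(=O)c1sc(-c2cccc(NC(=O)c3cccc(F)c3)c2)nc1Nc1ccc(N2CCN(C)CC2)cc1` differs from it by fluoro in place of hydrogen on an aromatic carbon and gives 85.2%; the step of a number 8.1 percentage points higher from compound 1 to compound 2 (within the scatter). Compound 3 `CN1CCN(c2ccc(Nc3nc(-c4cccc(NC(=O)c5ccccc5)c4)sc3C(N)=O)cc2)CC1` differs from compound 1 by amino in place of ethoxy on a carbonyl carbon. In this assay compound 3 gives 98.1%, which is the highest of the three measured values, the step being a number 21 percentage points higher from compound 1 to compound 3 (beyond the scatter).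

Compound 4 `CN1CCN(c2ccc(Nc3nc(-c4cccc(NC(=O)c5cccc(F)c5)c4)sc3C(N)=O)cc2)CC1` is unmeasured and differs from compound 3 by fluoro in place of hydrogen on an aromatic carbon, the same change that turns compound 1 into compound 2, placed on the same kind of ring at the same position. Because a number 8.1 percentage points higher from compound 1 to compound 2 (within the scatter), and because compound 3 already reaches 98.1%, compound 4 is expected to show almost no further rise, an estimated step of a number 0.1 percentage points lower from compound 3 to compound 4 (within the scatter). The estimate for compound 4 is 98%, expected to lie between 92% and 100%.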

Compound 4, a percentage reported as inhibition, at one concentration (the size of the read-out at that concentration, not a potency): 16.2%
Beside the measured number, compound 4's estimate is 81.8 percentage points above it, and the stated range ends above it.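

In this assay, fluoro in place of hydrogen gives a step of a number 81.9 percentage points lower from compound 3 to compound 4 (beyond the scatter), so a change that stayed within the scatter on the core of compound 1 does not carry over to the core of compound 3: the same change on two cores in this assay, a number 8.1 percentage points higher (within the scatter) from compound 1 to compound 2 and a number 81.9 percentage points lower (beyond the scatter) from compound 3 to compound 4, 90 percentage points apart, beyond the scatter of two such steps

Seen from the other side, amino in place of ethoxy gives a step of a number 69 percentage points lower from compound 2 to compound 4 (beyond the scatter) when the fluoro is present, the opposite direction to the rise seen without it: the same change on two cores in this assay, a number 21 percentage points higher (beyond the scatter) from compound 1 to compound 3 and a number 69 percentage points lower (beyond the scatter) from compound 2 to compound 4, 90 percentage points apart, beyond the scatter of two such steps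

Across these four compounds, then, the outcome of each change depends on the other, so the two cannot simply be added; this does not show why that happens, and with one pair of cores and a single concentration it gives no general rule and no potency.

Going by these compounds, it remains open whether the fall belongs to fluoro alone or would also follow with chloro or methoxy on the same ring. On these data alone, it is equally open how a carboxylic acid or a methylamide in place of the amino would respond to the fluoro.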